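From 2-fluorophenyl to 4-fluorophenyl on a shared core

The source may hold more compounds than are shown below. What is called first, only, known or untested is meant among the compounds shown, and "the series" means these compounds.

Measured in an ADME assay on THP-1 cells (Homo sapiens) for cytotoxicity, read by flow cytometry and propidium iodide staining, with a stated time of 72 h; on this read-out lower numbers stand for stronger inhibition and higher numbers for weaker inhibition:
- compound 1 `CC(=O)Nc1ccc2oc(-c3ccc(F)cc3)cc(=O)c2c1`: 22000 nM
- compound 2 `COc1ccccc1-c1oc2ccc(NC(C)=O)cc2c(=O)c1O`: > 125000 nM
- compound 3 `CC(=O)Nc1ccc2oc(-c3ccccc3F)c(O)c(=O)c2c1`: 47000 nM

Compound 2 stands at > 125000 nM, which is a limit of the assay and not a number. Of the two actual numbers, compound 3 holds the higher at 47000 nM, and compound 1 lies lower at 22000 nM, a gap beyond the usual scatter.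

The next compound is compound 4 `CC(=O)Nc1ccc2oc(-c3ccc(F)cc3)c(O)c(=O)c2c1`, and it is reached by 4-fluorophenyl in place of 2-fluorophenyl on an aromatic carbon. This puts 4-fluorophenyl in place of 2-fluorophenyl on an aromatic carbon, next to the ring oxygen and ortho to a hydroxy group.

Within the data shown here, no measured step makes this same change. Among the measured compounds shown here, the only one at this place is an at least 2.6-fold lower number from compound 2 to compound 3 (0.42 log units; beyond the scatter), with fluoro in place of methoxy, and it shows only that a change here can move the number in this assay. Compound 1, which also bears 4-fluorophenyl, gives 22000 nM, and on that value a small move toward a lower number is expected, probably not beyond the scatter. The expected size is a 1.2-fold lower number from compound 3 to compound 4 (0.09 log units; within the scatter). For compound 4 the estimate is 38000 nM, with a range of 17000 nM to 85000 nM.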

Compound 4, half-maximal inhibitory concentration: 26000 nM
For compound 4 the middle estimate is 1.5-fold (0.16 log units) above the measured one; the range from low to high includes it.
By their numbers in this assay, from the lowest: compounds 1, 4 and 3 (each within the scatter of the next, the first and the last beyond it). At a limit, above all of these: compound 2.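

In this assay, 4-fluorophenyl in place of 2-fluorophenyl, on the aromatic carbon ortho to a hydroxy group, gives a 1.8-fold lower number from compound 3 to compound 4 (0.26 log units; within the scatter), so this change alone does not separate the two compounds. Hydroxy in place of hydrogen on that same ring, a change that none of the earlier compounds isolated, gives a 1.2-fold higher number from compound 1 to compound 4 (0.07 log units; within the scatter), so with 4-fluorophenyl in place, the read-out in this assay does not distinguish the compound with the hydroxy group from the one without it. By contrast, 4-fluorophenyl in place of 2-methoxyphenyl gives an at least 4.8-fold lower number from compound 2 to compound 4 (0.68 log units; beyond the scatter), a step beyond the scatter whose full size stays open, since compound 2 carries a limit of the assay and not a number: the limit of > 125000 nM in this assay, at which 1 of the 4 values shown sits.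

Going by these compounds, whether hydroxy in place of hydrogen would behave the same way alongside 2-fluorophenyl remains open, as does whether the fluoro group gives the same reading on the remaining ring carbons of the phenyl group. Also open, on these data alone, is whether an amine or a carboxylic acid on that phenyl ring, or a longer chain on the amide carbonyl, would move the number in this assay beyond the scatter.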